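The source may report more compounds than this note shows. Statements on the series, on what has been measured and on what is new or still open speak of the compounds shown alone.

Compound 1 `CC(C)(NC(=O)c1cc(F)cc2cc(-c3ccc(Cl)cc3)oc12)c1nnn[nH]1` and compound 2 `O=C(NC1(C(=O)O)CCCC1)c1cc(F)cc2cc(-c3ccc(Cl)cc3)oc12` share the same core and differ only in the group attached to an amide-type nitrogen. In an assay on isolated protein for inhibition of endoplasmic reticulum aminopeptidase 1 (Homo sapiens), with stated times of 15 min and 20 min (a higher number here means a weaker inhibitor, a lower number a stronger inhibitor), compound 1 gives 275 nM. In this assay, among the compounds with values here, compound 2 gives 99 nM, the lowest of the two numbers so far, and the step of a 2.8-fold lower number from compound 1 to compound 2 (0.44 log units; beyond the scatter) separates them. Compound 3 `O=C(NC1(C(=O)O)CCCCC1)c1cc(F)cc2cc(-c3ccc(Cl)cc3)oc12` has not yet been measured; it differs from compound 2 by 1-carboxycyclohexyl in place of 1-carboxycyclopentyl on an amide-type nitrogen. Within the data shown here, no measured step tests a change of ring size alone: the step from compound 1 to compound 2 exchanges the whole group, so it bears on this change only loosely. Because that step was a 2.8-fold lower number from compound 1 to compound 2 (0.44 log units; beyond the scatter) while the present change is much smaller, little or no step beyond the scatter is expected, namely a 1.1-fold lower number from compound 2 to compound 3 (0.04 log units; within the scatter). For compound 3 the expected value in this assay is 90 nM, in a range from 40 nM to 220 nM.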

Compound 3, half-maximal inhibitory concentration: 34 nM
Compound 3: middle estimate off by 2.6-fold (0.42 log units), on the high side; measured number below the stated range.
By their numbers in this assay, from the lowest: compound 3; then compound 2; then compound 1.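

With the carboxylic acid kept and only the five-membered carbon ring replaced by a six-membered one, this assay shows a 2.9-fold lower number from compound 2 to compound 3 (0.46 log units; beyond the scatter), so ring size on this amide-type nitrogen matters in its own right and is not a minor detail. Exchanging 1-(1H-tetrazol-5-yl)-1-methylethyl for 1-carboxycyclohexyl gives an 8.1-fold lower number from compound 1 to compound 3 (0.91 log units; beyond the scatter), which makes 1-carboxycyclohexyl the group with the lowest number of the three shown at this place. Nothing available explains why the six-membered ring gives the lower number.

The compounds shown leave open whether a seven-membered carbon ring would lower the number further or raise it again. They also leave open whether a 1-(1H-tetrazol-5-yl)cyclohexyl group, with a tetrazole in place of the carboxylic acid, would benefit from the six-membered ring in the same way.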